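The source may report more compounds than this note shows. Statements on the series, on what has been measured and on what is new or still open speak of the compounds shown alone.

Values so far in a functional assay on MCF7 cells (Homo sapiens) for inhibition, read by MTT assay, with a stated time of 72 h; on this read-out lower numbers stand for stronger inhibition and higher numbers for weaker inhibition

- compound 1 `COc1ccc(C(=O)/C=C/c2cc(OC)c(OC)cc2OC)cc1` gives 33900 nM
- compound 2 `COc1cc(OC)c(OC)cc1/C=C/C(=O)c1cc(Cl)ccc1O` gives > 150000 nM as a limit of the assay, not a number
- compound 3 `COc1cc(OC)c(OC)cc1/C=C/C(=O)c1ccc(C)cc1` gives 33000 nM

Within the data shown here, compound 3 shares its level with the only other number, and the remaining entry is a limit. Next is compound 4 `COc1cc(OC)c(OC)cc1/C=C/C(=O)c1ccc([N+](=O)[O-])cc1` with nitro in place of methyl on an aromatic carbon, para to a large group (nitro in place of methyl on an aromatic carbon). The nearest measured swap is methyl in place of methoxy on an aromatic carbon, which gave a 1.0-fold lower number from compound 1 to compound 3 (0.01 log units; within the scatter) and so no change beyond the scatter. The larger steps, an at least 4.4-fold higher number from compound 1 to compound 2 (0.64 log units; beyond the scatter) and an at least 4.5-fold lower number from compound 2 to compound 3 (0.65 log units; beyond the scatter) as the other, exchange the whole group on the carbonyl carbon and involve 5-chloro-2-hydroxyphenyl, so they bear less directly on this swap. A single close step is thin support, so the range stays wide. A step of a 1.2-fold lower number from compound 3 to compound 4 (0.07 log units; within the scatter) is expected in this assay with no shift beyond the scatter in either direction. The estimate for compound 4 is 28000 nM within an expected range of 9000 nM to 85000 nM on this read-out.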

Compound 4, half-maximal inhibitory concentration: > 150000 nM
Compound 4 ended at the assay's limit (the forecaster's own chance of this, stated with the estimate: 10%); middle value at least 5.3-fold (0.72 log units) from the limit.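

In this assay, nitro in place of methyl gives an at least 4.5-fold higher number from compound 3 to compound 4 (0.65 log units; beyond the scatter), and nitro in place of methoxy gives an at least 4.4-fold higher number from compound 1 to compound 4 (0.64 log units; beyond the scatter), so the read-out at this position, on an aromatic carbon para to a large group, does depend on the group, although methyl and methoxy there read within the scatter of each other. Compound 4 gives > 150000 nM, which is a limit of the assay and not a number. Both steps therefore set only a lower bound on the size of the change, and compound 4 sits at the same limit as compound 2: the limit of > 150000 nM in this assay, at which 2 of the 4 values shown sit.

From the compounds shown here alone, how an amine or a carboxylic acid at this position would read stays open. Going by these compounds, the true distance of compound 4 from compound 3 also stays open, since the limit hides it.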